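This account rests on a few compounds, and the source may have more. Where it says the series, first, only, none or still open, it means among the compounds named here.

Measured so far in a functional assay on Bel-7402 cells (Homo sapiens) for cytotoxicity, read by MTT assay; a higher number here means a weaker inhibitor, a lower number a stronger inhibitor:
- compound 1 `COc1cccc(/C=C/C(=O)c2sc(Nc3ccc(Cl)c(Cl)c3)nc2C)c1`: > 25000 nM
- compound 2 `Cc1ccc(Nc2nc(C)c(C(=O)/C=C/c3ccccc3)s2)cc1`: > 25000 nM
- compound 3 `COc1cc(/C=C/C(=O)c2sc(Nc3ccc(Cl)c(Cl)c3)nc2C)cc(OC)c1OC`: > 25000 nM

Compound 1 gives > 25000 nM in this assay, which is a limit of the assay and not a number. Compound 2 likewise gives > 25000 nM, a limit. Compound 3 gives > 25000 nM, again a limit. Within the data shown here, every value shown sits at the limit of > 25000 nM in this assay, at which 3 of the 3 values shown sit, so no measured step can be sized and compound 1 stands nowhere distinct among the three.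

Compound 4 `Cc1nc(Nc2ccc(Cl)c(Cl)c2)sc1C(=O)/C=C/c1ccc(Cl)cc1` differs from compound 1 by 4-chlorophenyl in place of 3-methoxyphenyl on a double-bonded chain carbon bound to a double-bonded chain carbon. The three limits give no guide to the size or direction of such a change. Compound 4 is therefore expected near 30000 nM, with a range of 8000 nM to 100000 nM. The step that the limit leaves unreadable from compound 1 to compound 4 is estimated as none beyond the scatter, most likely ending at a limit again.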

Compound 4, half-maximal inhibitory concentration: > 25000 nM
Compound 4: no number, only a limit; the forecaster's own chance of this, stated with the estimate: 75%; the middle value does not contradict the limit.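

No step can be read from compound 1 to compound 4, since both values are limits and not numbers: the limit of > 25000 nM in this assay, at which 4 of the 4 values shown sit.

The compounds shown leave open which change on the shared core, if any, would give a readable value.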